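The compounds below may be only part of what the source reports. "The series", "measured", "known", "first", "only" and "open" are said of these compounds alone.

Compound 1 `CCCCC(C)n1ccc2cc(/C(C)=C/C(=O)Nc3ccccc3OCCCC(=O)O)ccc21` — 6 nM
Compound 2 `C/C(=C\C(=O)Nc1ccccc1OCCCC(=O)O)c1ccc2c(ccn2Cc2ccc(F)cc2)c1` — 97 nM

In an assay on Prostate gland for inhibition of steroid 5-alpha-reductase (Rattus norvegicus) (a higher number here means a weaker inhibitor, a lower number a stronger inhibitor), compound 1 gives 6 nM, while compound 2 gives 97 nM. Among the measured compounds shown here, of the two numbers measured so far, compound 2 stands highest, with compound 1 as its only neighbour, so compound 2 is the weaker inhibitor of the pair. For the measured compounds named here, the single measured step, a 16-fold higher number from compound 1 to compound 2 (1.21 log units; beyond the scatter), arose from the change of 4-fluorobenzyl in place of 1-methylpentyl on the aromatic nitrogen.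

Compound 3 `C/C(=C\C(=O)Nc1ccccc1OCCCC(=O)O)c1ccc2c(ccn2C(c2ccccc2)C(C)C)c1` has not yet been measured. It differs from compound 2 in one place: 2-methyl-1-phenylpropyl in place of 4-fluorobenzyl on an aromatic nitrogen. The group that enters shares the branching at its attachment carbon with the 1-methylpentyl of compound 1 and keeps a six-membered aromatic ring like the 4-fluorobenzyl of compound 2. Going by the values given here, the one step that bears on this, a 16-fold higher number from compound 1 to compound 2 (1.21 log units; beyond the scatter), is large, so a step for compound 3 in this assay beyond the scatter seems plausible, towards a lower number, though partial because compound 3 is not compound 1. Compound 3 is therefore expected at 25 nM, in the range 6 nM to 100 nM, which means an expected step of a 3.9-fold lower number from compound 2 to compound 3 (0.59 log units; beyond the scatter).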

Compound 3, half-maximal inhibitory concentration: 25 nM
Compound 3: middle estimate and measured number agree at the digits printed; measured number inside the range.
By their numbers in this assay, from the lowest: compound 1; then compound 3; then compound 2.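

Among the compounds shown here, at this position on the aromatic nitrogen, the 4-fluorobenzyl group of compound 2 is not the only outcome for a group carrying a six-membered aromatic ring: in this assay, 2-methyl-1-phenylpropyl gives a 3.9-fold lower number from compound 2 to compound 3 (0.59 log units; beyond the scatter) and so recovers part of what the earlier step had lost. The aromatic ring does not match the purely aliphatic 1-methylpentyl, however, since the comparison with that group gives a 4.2-fold higher number from compound 1 to compound 3 (0.62 log units; beyond the scatter) and leaves compound 1 with the lowest number of the three. The change from compound 2 to compound 3 removes the fluorine and adds branching at the attachment carbon in one step, and nothing available here explains why the number falls.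

The compounds shown leave open whether the branching or the loss of fluorine carries the step, a question that a plain benzyl or a 1-phenylethyl group on the same nitrogen would address. They also leave open how a saturated ring such as cyclohexyl, or a chain ending in an amine, would fare at this position.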